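Moving a methyl within the cyanoguanidine tail of compound 1

A few compounds are considered here, and "the series" means these few. Any claim that something is new, unique, unknown or untested is made for them only; others in the source may bear on it.

In a functional assay on the whole organism with Rattus norvegicus as the target, at a dose of 100 mg/kg (a higher number here means more inhibition at the dose given (going by the name of the read-out), a lower number less inhibition), compound 1 `CN(C)/C(=N/CCCCn1nc(-c2ccccc2)ccc1=O)NC#N` gives 80.7%, the highest of the two numbers in hand. Compound 2 `C#CCN/C(=N/CCCCn1nc(-c2ccccc2)ccc1=O)NC#N` gives -12.9% in this assay; the step was a number 93.6 percentage points lower from compound 1 to compound 2 (beyond the scatter). Compound 3 `C/N=C(/NC#N)N(C)CCCCn1nc(-c2ccccc2)ccc1=O` differs from compound 1 by a group of 8 heavy atoms (4 carbon, 4 nitrogen; no ring) in place of a group of 8 heavy atoms (4 carbon, 4 nitrogen; no ring), on a saturated chain carbon, four bonds along the chain from an aromatic nitrogen. Within the data shown here, the only measured step touches the same tail and was large, so some loss is expected, though a rearrangement is not the same change. The step is expected to be a number 45.7 percentage points lower from compound 1 to compound 3 (beyond the scatter). Compound 3 is estimated at 35%, between -10% and 80%.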

Compound 3, a percentage reported as inhibition, in the whole organism at one dose (the size of the read-out at that dose, not a potency): 27%
Compound 3: the middle estimate sits 8 percentage points above what was measured; the range from low to high includes it.
By their numbers in this assay, from the lowest: compound 2; then compound 3; then compound 1.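

In this assay the rearrangement alone brings a number 53.7 percentage points lower from compound 1 to compound 3 (beyond the scatter), although the group that leaves and the group that enters hold the same atoms and the same counts of hydrogen-bond donors and acceptors. At this place, on a saturated chain carbon, how the atoms are joined therefore matters, not only which atoms are present, something the propargylamino change in compound 2 could not show, as it swapped the atoms as well. Nothing available explains this loss.

Still open, as far as these compounds go, is how a methylamino or a pyrrolidine group would fare in place of dimethylamino. A shorter chain leading to the tail is also untested in what is shown here.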